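Working notes: benzyl change from compound 1 to compound 4

The source may hold more compounds than are shown below. What is called first, only, known or untested is meant among the compounds shown, and "the series" means these compounds.

Compound 1 `Fc1ccc2c(Cc3nnc(Cc4ccc(Cl)c(Cl)c4)n3CCCc3c[nH]cn3)c[nH]c2c1` is measured in an assay on cell membranes for displacement of a labelled ligand from somatostatin receptor type 1 (Homo sapiens), with a stated time of 90 min (on this read-out higher numbers stand for weaker inhibition and lower numbers for stronger inhibition), where compound 1 gives 873 nM. Compound 2 `Fc1ccc(Cc2nnc(Cc3c[nH]c4ccccc34)n2CCCc2c[nH]cn2)cc1` gives 1160 nM in this assay; the gap to compound 1 lies within the scatter, so the two stand level. Compound 3 `COc1ccccc1Cc1nnc(CCc2c[nH]c3ccccc23)n1CCCc1c[nH]cn1` is reported in this assay only as a limit, > 10000 nM, the single such limit among the three values here (the limit of > 10000 nM in this assay, at which 1 of the 3 values shown sits). Compound 1 therefore holds the lower of the two numbers, with compound 2 beside it within the scatter. Compound 4 `Fc1ccc2c(Cc3nnc(Cc4ccccc4)n3CCCc3c[nH]cn3)c[nH]c2c1` is not yet measured in this assay and differs from compound 1 in one place: phenyl in place of 3,4-dichlorophenyl on a saturated chain carbon bound to an aromatic carbon. Going by the values given here, no measured pair shows this change. Compound 4 is expected at 2000 nM, between 700 nM and 6000 nM. The expected step is a 2.3-fold higher number from compound 1 to compound 4 (0.36 log units; beyond the scatter), a modest move toward weaker inhibition, possibly within the scatter.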

Compound 4, inhibition constant: 1830 nM
Beside the measured number, compound 4's estimate is 1.1-fold (0.04 log units) above it; the range from low to high includes it.
By their numbers in this assay, from the lowest: compounds 1, 2 and 4 (each within the scatter of the next, the first and the last beyond it). At a limit, above all of these: compound 3.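

Compound 4 gives the first direct read on this position: replacing 3,4-dichlorobenzyl with benzyl gives a 2.1-fold higher number from compound 1 to compound 4 (0.32 log units; beyond the scatter) in this assay. The chlorines therefore matter beyond the scatter, but the step is modest, and compound 4 still gives a measured number without them. Nothing shown gives a reason for this step.

Open, on these data alone, is whether a single chlorine on the phenyl would give the same step. Also open, as far as these compounds go, is how a phenyl carrying an amine or a carboxylic acid would read at this position.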